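The source may report more compounds than this note shows. Statements on the series, on what has been measured and on what is new or still open speak of the compounds shown alone.

Measured in a functional assay on A549 cells (Homo sapiens) for antiproliferative activity, read by MTT assay, with a stated time of 48 h; a lower number here means a stronger inhibitor, a higher number a weaker inhibitor:
- compound 1 `Oc1ccc2ccccc2c1C(Nc1nc2ccccc2s1)c1cn(-c2ccccc2)nc1-c1ccccc1`: 36200 nM
- compound 2 `COc1ccc(-c2nn(-c3ccccc3)cc2C(Nc2nc3ccc(OC)cc3s2)c2c(O)ccc3ccccc23)cc1`: 28100 nM
- compound 3 `COc1ccc2nc(NC(c3cn(-c4ccccc4)nc3-c3cccc(I)c3)c3c(O)ccc4ccccc34)sc2c1`: 39300 nM

The three values sit close together. Compound 3, at 39300 nM, cannot be told apart from either of the other two, as both gaps lie within the scatter of the measurement.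

Compound 4 `COc1ccc2nc(NC(c3cn(-c4ccccc4)nc3-c3ccccc3)c3c(O)ccc4ccccc34)sc2c1` has not yet been measured. It carries hydrogen in place of iodo on an aromatic carbon of a six-membered aromatic ring of carbon only, meta to a large group, so that 3-iodophenyl becomes phenyl: hydrogen in place of iodo on an aromatic carbon.

Among the compounds with values here, only one measured step touches this group. It puts 3-iodophenyl in place of 4-methoxyphenyl, and a 1.4-fold higher number from compound 2 to compound 3 (0.15 log units; within the scatter) stays within the scatter. Though its core differs from that of compound 4, compound 1 also carries the phenyl group and gives 36200 nM, again close to compound 3. The data therefore give no reason to expect a change in either direction beyond the scatter in this assay. The expected change is small, with a 1.2-fold lower number from compound 3 to compound 4 (0.08 log units; within the scatter) as the estimated step. For compound 4 the estimated value is 33000 nM, with an expected range of 19000 nM to 55000 nM.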

Compound 4, half-maximal inhibitory concentration: 44600 nM
Compound 4: middle estimate off by 1.4-fold (0.13 log units), on the low side; the range from low to high includes it.
By their numbers in this assay, from the lowest: compounds 2, 1, 3 and 4 (each within the scatter of the next).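

Hydrogen in place of iodo on this aromatic carbon, meta to a large group, gives a 1.1-fold higher number from compound 3 to compound 4 (0.05 log units; within the scatter) in this assay, so phenyl cannot be told apart from 3-iodophenyl here. Hydrogen in place of methoxy on an aromatic carbon gives a 1.6-fold higher number from compound 2 to compound 4 (0.20 log units; within the scatter), which means that phenyl, 3-iodophenyl and 4-methoxyphenyl now form a set of three aryl groups that all lie within the scatter of one another. Within the data shown here, with the aryl group held as phenyl, the methoxy group on the shared core also makes no readable difference, as methoxy in place of hydrogen on an aromatic carbon gives a 1.2-fold higher number from compound 1 to compound 4 (0.09 log units; within the scatter), a comparison that the earlier compounds could not offer.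

The compounds shown leave open whether any group on this ring can shift the number beyond the scatter at all, for instance an amine, a carboxylic acid or a longer chain in place of the iodo. Nothing shown here offers an explanation for these numbers.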